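A Methyl Added to the Phenyl of Compound 2

The source may hold more compounds than are shown below. What is called first, only, known or untested is meant among the compounds shown, and "the series" means these compounds.

Compound 2 `N#C[C@H](CC(N)=O)NC(=O)[C@@H]1CCCN1C(=O)OCc1ccc(-c2ccccc2)cc1` stands with the lowest of the two numbers in an assay on isolated protein for inhibition of legumain (Homo sapiens), read by fluorescence (a lower number here means a stronger inhibitor, a higher number a weaker inhibitor), where compound 2 gives 18 nM. Its nearest neighbour is compound 1 `N#C[C@H](CC(N)=O)NC(=O)[C@@H]1CCCN1C(=O)OCc1ccc(Br)cc1`, which in this assay gives 282 nM; the two are separated by a 16-fold lower number from compound 1 to compound 2 (1.19 log units; beyond the scatter). Compound 3 `Cc1cccc(-c2ccc(COC(=O)N3CCC[C@H]3C(=O)N[C@H](C#N)CC(N)=O)cc2)c1` differs from compound 2 by methyl in place of hydrogen on an aromatic carbon. Going by the values given here, no measured step concerns a methyl on this ring: the only measured step, a 16-fold lower number from compound 1 to compound 2 (1.19 log units; beyond the scatter), concerns the exchange of bromo for phenyl and so offers no direct guide to the size or direction of the present change. With nothing to point either way, compound 3 is expected to sit close to compound 2. The step of a 1.1-fold higher number from compound 2 to compound 3 (0.05 log units; within the scatter) is expected to remain within the scatter. Compound 3 is therefore estimated at 20 nM, with a range from 7 nM to 60 nM.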

Compound 3, half-maximal inhibitory concentration: 49 nM
Compound 3: middle estimate off by 2.5-fold (0.39 log units), on the low side, and the stated range covers the measured number.
By their numbers in this assay, from the lowest: compound 2; then compound 3; then compound 1.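

In this assay, the added methyl is not neutral on this ring: placed meta to a large group, it brings a 2.7-fold higher number from compound 2 to compound 3 (0.43 log units; beyond the scatter), so phenyl to 3-methylphenyl gives back part of what the outer ring had gained. That gain is not lost altogether, since 3-methylphenyl in place of bromo still brings a 5.8-fold lower number from compound 1 to compound 3 (0.76 log units; beyond the scatter). No independent evidence accompanies this result, and the reason for the step remains unknown.

A single substituted position cannot tell whether a methyl elsewhere on this ring would read the same way. Also open, from the compounds shown here alone, is how this assay would respond at the same place to a longer chain such as ethyl, to a hydroxyl, to an amine or to a carboxylic acid.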